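Swapping Bromo for Fluoro on a Shared Core

The source may report more compounds than this note shows. Statements on the series, on what has been measured and on what is new or still open speak of the compounds shown alone.

Three compounds built on one shared core were tested in a functional assay on C6 cells (Rattus norvegicus) for cytotoxicity, read by MTT assay, with a stated time of 24 h, tested at 50 ug/mL; a lower number here means a stronger effect, a higher number a weaker effect of the compound at the concentration tested. Compound 1 `Cc1ccc(-c2cs/c(=N/NC(=O)CSc3nnnn3-c3ccccc3)n2-c2ccccc2)cc1` gives 29.5%, compound 2 `Cn1nnnc1SCC(=O)N/N=c1/scc(-c2ccccc2)n1-c1ccccc1` gives 56.2%, and compound 3 `O=C(CSc1ncccn1)N/N=c1/scc(-c2ccc(Br)cc2)n1-c1ccccc1` gives 69%, the highest of the three, beyond the scatter from each of the other two. Compound 4 `O=C(CSc1ncccn1)N/N=c1/scc(-c2ccc(F)cc2)n1-c1ccccc1` differs from compound 3 by a single change: fluoro in place of bromo on an aromatic carbon. Within the data shown here, no measured pair shows this same change, so nothing here tells its size directly. The step from compound 3 to compound 4 is expected to be small, a number 7 percentage points lower from compound 3 to compound 4 (within the scatter), and may well fall within the scatter. Compound 4 is therefore estimated to give 62% in this assay, with an expected range from 42% to 82%.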

Compound 4, a percentage reported as activity, at one concentration (the size of the read-out at that concentration, not a potency): 55.5%
Compound 4: middle estimate off by 6.5 percentage points, on the high side; the measured number falls inside the stated range.
By their numbers in this assay, from the lowest: compound 1; then compounds 4 and 2 (each within the scatter of the next); then compound 3.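

Compounds 1, 2 and 3 differ in more than one place, so they could not isolate any single change. Going from 4-bromophenyl to 4-fluorophenyl gives [ a number 13.5 percentage points lower from compound 3 to compound 4 (beyond the scatter) ] in this assay, which shows that the group at this position alone can shift the read-out, with fluoro giving the stronger effect at the concentration tested. No measurement here bears on the reason for this step.

Still open, going by these compounds, is how chloro or an amine at this same place would compare. It is also unknown whether the step would hold with a different group on the sulfur side of the molecule.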